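Bromo-to-hydrogen exchange on two related cores

The compounds below may be only part of what the source reports. "The series", "measured", "known", "first", "only" and "open" are said of these compounds alone.

Compound 1 `COc1ccc2c(c1)c(/C=N\NC(=O)c1c[nH]c3ccc(Br)cc13)cn2Cc1ccc(Cl)cc1` and compound 2 `COc1ccc2c(c1)c(/C=N\NC(=O)c1c[nH]c3ccccc13)cn2Cc1ccc(Cl)cc1` share one core; in a functional assay on MCF7 cells (Homo sapiens) for cytotoxicity (on this read-out lower numbers stand for stronger inhibition and higher numbers for weaker inhibition), compound 1 gives 29100 nM and compound 2 gives 8700 nM. Between them stands (hydrogen in place of bromo on an aromatic carbon), and the step that this change made is a 3.3-fold lower number from compound 1 to compound 2 (0.52 log units; beyond the scatter). Compound 3 `COc1ccc(Cn2cc(/C=N\NC(=O)c3c[nH]c4ccc(Br)cc34)c3ccc(F)cc32)cc1` carries the bromo group on a second core; in this assay compound 3 gives 31700 nM, close to compound 1 and beyond the scatter from compound 2. How the core of compound 3 differs from the core of compound 1 is not broken down here. Compound 4 `COc1ccc(Cn2cc(/C=N\NC(=O)c3c[nH]c4ccccc34)c3ccc(F)cc32)cc1` is not yet measured; from compound 3 it differs by hydrogen in place of bromo on an aromatic carbon, the same change as that from compound 1 to compound 2, at a place described in the same words. For the measured compounds named here, only one instance of the change is measured, so the expectation rests on that single step. The expected step is a 3.2-fold lower number from compound 3 to compound 4 (0.50 log units; beyond the scatter) in this assay, since the measured instance gave a 3.3-fold lower number from compound 1 to compound 2 (0.52 log units; beyond the scatter). The starting point is compound 3 with 31700 nM. Compound 4 is estimated at 10000 nM, with a range from 4000 nM to 25000 nM.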

Compound 4, half-maximal inhibitory concentration: 13100 nM
For compound 4 the middle estimate is 1.3-fold (0.12 log units) below the measured one; low and high end bracket the measured number.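

On the second core, the exchange of 5-bromo-1H-indol-3-yl for 1H-indol-3-yl gives a 2.4-fold lower number from compound 3 to compound 4 (0.38 log units; beyond the scatter) in this assay. Set beside the earlier instance, the step keeps its direction and its size does not differ between the two cores: the same change on two cores in this assay, a 3.3-fold lower number (0.52 log units; beyond the scatter) from compound 1 to compound 2 and a 2.4-fold lower number (0.38 log units; beyond the scatter) from compound 3 to compound 4, 1.4-fold (0.14 log units) apart, within the scatter of two such steps. For the compounds shown here, in this series the change therefore carries over from the core of compound 1 to the core of compound 3, but that rests on only two pairs, says nothing about any further core, and does not show why loss of the bromo group goes with the lower number.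

Among the compounds shown, the aromatic carbon in question carries only bromo or hydrogen, so it remains open how an amine, a nitrile or a carboxylic acid at that place would read in this assay. From the compounds shown here alone, it also remains open whether the same step would appear with other groups on the indole nitrogen of the hydrazone-linked core or in other cell lines.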